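Swapping a Bromophenol for a Styryl Group

This account rests on a few compounds, and the source may have more. Where it says the series, first, only, none or still open, it means among the compounds named here.

Three measured compounds share one core and differ only in the aromatic group attached to the carbon with a double bond to nitrogen. Compound 1 `O=C(CSc1nnc(-c2ccncc2)n1-c1ccccc1)N/N=C/c1ccc(O)cc1` carries a 4-hydroxyphenyl there. In a functional assay on HCT-116 cells (Homo sapiens) for inhibition, read by MTT assay, with a stated time of 48 h (on this read-out lower numbers stand for stronger inhibition and higher numbers for weaker inhibition), compound 1 reaches only a limit of the assay, > 50000 nM, which is the limit of > 50000 nM in this assay, at which 1 of the 3 values shown sits. Compound 2 `O=C(CSc1nnc(-c2ccncc2)n1-c1ccccc1)N/N=C/c1ccc(Br)cc1` carries a 4-bromophenyl and gives 4500 nM in this assay. Compound 3 `O=C(CSc1nnc(-c2ccncc2)n1-c1ccccc1)N/N=C/c1cc(Br)ccc1O` carries a 5-bromo-2-hydroxyphenyl and gives 1990 nM in this assay, the lowest number among the measured compounds; its nearest neighbour is compound 2, since a 2.3-fold lower number from compound 2 to compound 3 (0.35 log units; beyond the scatter). The other steps are an at least 11-fold lower number from compound 1 to compound 2 (1.04 log units; beyond the scatter) and an at least 25-fold lower number from compound 1 to compound 3 (1.40 log units; beyond the scatter).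

Compound 4 `O=C(CSc1nnc(-c2ccncc2)n1-c1ccccc1)N/N=C/C=C/c1ccccc1` is not yet measured. The change is 2-phenylethenyl in place of 5-bromo-2-hydroxyphenyl on a carbon with a double bond to nitrogen. Among the measured compounds shown here, no measured step covers this exchange directly. The closest guide is that the bromine mattered: an at least 11-fold lower number from compound 1 to compound 2 (1.04 log units; beyond the scatter), and compound 4 keeps neither the bromine nor the hydroxy group while adding a double bond outside the aromatic ring. On that basis a modest to large rise in the number is expected, that is a 4.0-fold higher number from compound 3 to compound 4 (0.60 log units; beyond the scatter). Compound 4 is therefore estimated at 8000 nM in this assay, within a range from 2000 nM to 40000 nM.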

Compound 4, half-maximal inhibitory concentration: 6150 nM
The estimate for compound 4 lay 1.3-fold (0.11 log units) above the measured number, within the range that was stated.
By their numbers in this assay, from the lowest: compound 3; then compounds 2 and 4 (each within the scatter of the next). At a limit, above all of these: compound 1.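

Compound 4 carries no bromine, yet in this assay replacing 4-bromophenyl with 2-phenylethenyl gives a 1.4-fold higher number from compound 2 to compound 4 (0.14 log units; within the scatter), so at this position a low number does not depend on bromine in every group shown. Replacing 5-bromo-2-hydroxyphenyl with the same group gives a 3.1-fold higher number from compound 3 to compound 4 (0.49 log units; beyond the scatter), which leaves compound 3 with the lowest number, beyond the scatter of both compound 2 and compound 4. Replacing 4-hydroxyphenyl with 2-phenylethenyl gives an at least 8.1-fold lower number from compound 1 to compound 4 (0.91 log units; beyond the scatter), and that step starts from a limit of the assay rather than a number: the limit of > 50000 nM in this assay, at which 1 of the 4 values shown sits.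

The compounds shown do not separate the part played by the double bond outside the aromatic ring from that of the ring itself; a plain phenyl or a saturated 2-phenylethyl chain at this position would offer the direct comparison. On these data alone, it also remains open how 2-phenylethenyl would read in this assay with a bromine or a hydroxy group on its ring, or with an amine or a carboxylic acid there instead.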